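Acetamido to amino: working notes on the series

This account rests on a few compounds, and the source may have more. Where it says the series, first, only, none or still open, it means among the compounds named here.

Compound 1 `COc1ccc(S(=O)(=O)N2c3ccccc3CCC2C)cc1`: 5990 nM
Compound 2 `CC(=O)Nc1ccc(S(=O)(=O)N2c3ccccc3CCC2C)cc1`: 52000 nM

Among the compounds with values here, in an ADME assay on L6 cells (Rattus norvegicus) for cytotoxicity (on this read-out lower numbers stand for stronger inhibition and higher numbers for weaker inhibition), compound 2 gives 52000 nM, the higher of the two numbers so far, and compound 1 gives 5990 nM. The next compound to be read is compound 3 `CC1CCc2ccccc2N1S(=O)(=O)c1ccc(N)cc1`. Relative to compound 2, it carries hydrogen in place of acetyl on a nitrogen on an aromatic ring, which is hydrogen in place of acetyl on a nitrogen on an aromatic ring, or acetamido to amino when cut one bond further out.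

Within the data shown here, only one measured step bears on this change: an 8.7-fold higher number from compound 1 to compound 2 (0.94 log units; beyond the scatter), with acetamido in place of methoxy on an aromatic carbon. That step is modest but beyond the scatter. Among the measured compounds shown here, no measured pair shows the removal of acetyl itself, so this comparison is only a loose guide. Compound 2 sits at the top of the small range, so a move toward a lower number is expected, somewhat smaller than the measured step. The expected change is a 3.1-fold lower number from compound 2 to compound 3 (0.49 log units; beyond the scatter). In this assay the estimated value for compound 3 is 17000 nM, with an expected range from 6000 nM to 50000 nM.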

Compound 3, half-maximal inhibitory concentration: 35300 nM
Beside the measured number, compound 3's estimate is 2.1-fold (0.32 log units) below it; low and high end bracket the measured number.
By their numbers in this assay, from the lowest: compound 1; then compounds 3 and 2 (each within the scatter of the next).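

In this assay, the step for hydrogen in place of acetyl on a nitrogen on an aromatic ring is a 1.5-fold lower number from compound 2 to compound 3 (0.17 log units; within the scatter), so the acetyl on this nitrogen makes no difference that can be told from the scatter. Amino in place of methoxy on an aromatic carbon gives a 5.9-fold higher number from compound 1 to compound 3 (0.77 log units; beyond the scatter), and acetamido in the same place gives an 8.7-fold higher number from compound 1 to compound 2 (0.94 log units; beyond the scatter): both steps run in the same direction and lie beyond the scatter, so among these three compounds the read-out separates methoxy from the two nitrogen-linked groups, with no compound shown going against this. No measurement shown here explains why the read-out follows this pattern.

As far as these compounds go, it remains open whether a longer acyl chain such as propionyl, or a methyl group on the same nitrogen, would also stay within the scatter of compound 2 and compound 3. From the compounds shown here alone, it is equally open whether a dimethylamino group, a hydroxyl group, or a chlorine atom on the aromatic carbon would read with compound 1 or with the two nitrogen-linked compounds.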